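Moving a Chlorine on the Benzyl Group: Cytotoxicity Outlook

The source may hold more compounds than are shown below. What is called first, only, known or untested is meant among the compounds shown, and "the series" means these compounds.

Among the measured compounds shown here, compound 2 `O=C(Nc1cccc(F)c1)Nc1cc2ncncc2cc1OCc1ccccc1Cl` is the only compound with a plain number in an ADME assay on cells (Astrocyte, Homo sapiens) for cytotoxicity, read by WST assay, with a stated time of 72 h; on this read-out higher numbers stand for weaker inhibition and lower numbers for stronger inhibition: compound 2 gives 9400 nM. Compound 1 `O=C(Nc1cccc(Cl)c1)Nc1cc2ncncc2cc1OCc1ccccc1Cl` shares the whole core and differs from it only in one halogen. In this assay compound 1 reaches only a limit of the assay, > 10000 nM. The step of an at least 1.0-fold lower number from compound 1 to compound 2 (0.02 log units; that floor lies within the scatter) can therefore not be sized beyond that limit (the limit of > 10000 nM in this assay, at which 1 of the 2 values shown sits). Compound 3 `O=C(Nc1cccc(F)c1)Nc1cc2ncncc2cc1OCc1cccc(Cl)c1` has not yet been measured; its change from compound 2 is 3-chlorophenyl in place of 2-chlorophenyl on a saturated chain carbon bound to an oxygen on an aromatic ring. For the measured compounds named here, no measured step concerns this kind of change, so the only guide is that both measured compounds sit at weak inhibition. Compound 3 is therefore expected to stay close to compound 2, with an estimated step of a 1.1-fold higher number from compound 2 to compound 3 (0.03 log units; within the scatter). The estimate for compound 3 in this assay is 10000 nM, expected to lie between 4000 nM and 25000 nM.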

Compound 3, half-maximal inhibitory concentration: > 10000 nM
Compound 3 was reported as a limit (the forecaster's own chance of this, stated with the estimate: 50%); the middle value sits exactly at the limit.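

Changing 2-chlorobenzyl to 3-chlorobenzyl is the first change shown at this position, on the far side of the oxygen from the shared core, whereas the earlier step touched only a halogen on the other aromatic ring. In this assay, on these data alone, it gives an at least 1.0-fold higher number from compound 2 to compound 3 (0.02 log units; that floor lies within the scatter), so the move of the chlorine shows no sign of stronger inhibition, although the true size of the step stays unknown. Compound 3 is reported only as a limit, not a number, and the values now gather there: the limit of > 10000 nM in this assay, at which 2 of the 3 values shown sit.

The compounds shown leave open how far compound 3 lies from that limit. They also leave open whether an amine or a carboxylic acid on this benzyl ring, in place of the chlorine, would bring the value down to a plain number.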